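From 2-(trifluoromethyl)benzyl to 4-cyanobenzyl on a shared core

The compounds below may be only part of what the source reports. "The series", "measured", "known", "first", "only" and "open" are said of these compounds alone.

Values so far in a functional assay on HCT-116 cells (Homo sapiens) for antiproliferative activity, read by MTT assay, with a stated time of 24 h; on this read-out lower numbers stand for stronger inhibition and higher numbers for weaker inhibition
compound 1 `C#CCOc1ccc2c(=O)c(-c3cc(OC)c(OC)cc3OC)coc2c1` gives 8050 nM
compound 2 `COc1cc(OC)c(-c2coc3cc(OCc4ccc(Br)cc4)ccc3c2=O)cc1OC` gives 1980 nM
compound 3 `COc1cc(OC)c(-c2coc3cc(OCc4ccccc4C(F)(F)F)ccc3c2=O)cc1OC` gives 4760 nM

Compound 3 holds the middle of these three numbers. The step of a 1.7-fold lower number from compound 1 to compound 3 (0.23 log units; within the scatter) stays within the scatter, so those two values cannot be told apart, whereas the step of a 2.4-fold higher number from compound 2 to compound 3 (0.38 log units; beyond the scatter) lies beyond it.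

Compound 4 `COc1cc(OC)c(-c2coc3cc(OCc4ccc(C#N)cc4)ccc3c2=O)cc1OC` has 4-cyanophenyl in place of 2-(trifluoromethyl)phenyl on a saturated chain carbon bound to an oxygen on an aromatic ring. Among the compounds with values here, no measured compound carries the 4-cyanophenyl group, so no measured step matches this change directly. The nearest evidence is the modest step of a 4.1-fold lower number from compound 1 to compound 2 (0.61 log units; beyond the scatter), together with the step from the 4-bromophenyl group to the 2-(trifluoromethyl)phenyl group already given. The entering group resembles the 4-bromophenyl group in name, so the expectation leans only partly toward compound 2 (1980 nM) and stays cautious. A modest move to a lower number is expected, probably not beyond the scatter, and the estimated step is a 1.7-fold lower number from compound 3 to compound 4 (0.23 log units; within the scatter) in this assay. For compound 4 the expected value is 2800 nM, with an estimated range from 1100 nM to 7000 nM.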

Compound 4, half-maximal inhibitory concentration: 4220 nM
Estimate against measurement, compound 4: 1.5-fold (0.18 log units) below; low and high end bracket the measured number.
By their numbers in this assay, from the lowest: compound 2; then compounds 4, 3 and 1 (each within the scatter of the next).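

In this assay the change on the saturated chain carbon bound to an oxygen on an aromatic ring cannot be read as a gain or a loss, since a 1.1-fold lower number from compound 3 to compound 4 (0.05 log units; within the scatter) stays within the scatter, as does a 1.9-fold lower number from compound 1 to compound 4 (0.28 log units; within the scatter) in the comparison with the ethynyl group. The cyano group does not match the bromo group on the same aromatic carbon: a 2.1-fold higher number from compound 2 to compound 4 (0.33 log units; beyond the scatter) lies beyond the scatter and shows that a 4-substituted phenyl ring alone does not reproduce the number of compound 2, with compound 4 standing against any such pattern. No measurement is available that accounts for this difference between the two groups.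

On these data alone, whether the bromo result reflects something particular to that atom stays open, and a 4-chlorophenyl or 4-iodophenyl group would be the closest test of it. Also unresolved is how a 4-aminophenyl or 4-carboxyphenyl group, or a longer chain carrying the 4-bromophenyl group away from the oxygen, would read in this assay on the shared core.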